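A Methylated Tetrazole on a Longer Chain

The compounds below may be only part of what the source reports. "The series", "measured", "known", "first", "only" and "open" are said of these compounds alone.

Compound 1 `CCc1cc(C(C)=O)c(O)cc1OCCCCCCC(C)(C)C#N`: 11%
Compound 2 `CCc1cc(C(C)=O)c(O)cc1OCCCC(C)(C)C(N)=O`: 16%
Compound 3 `CCc1cc(C(C)=O)c(O)cc1OCCCC(C)(C)c1nnn[nH]1`: 28%

Compound 1 has the lowest number of the three in an assay on isolated protein for binding affinity to leukotriene B4 receptor (Homo sapiens), tested at 0.1 uM; a lower number here means less inhibition, a higher number more inhibition at the concentration tested (going by the name of the read-out); compound 2 sits within the scatter of it (a number 5 percentage points higher from compound 1 to compound 2 (within the scatter)), while compound 3 stands clearly apart (a number 17 percentage points higher from compound 1 to compound 3 (beyond the scatter)). Compound 4 `CCc1cc(C(C)=O)c(O)cc1OCCCCCC(C)(C)c1nnnn1C` changes compound 1 in one place: 1-methyl-1-(1-methyl-1H-tetrazol-5-yl)ethyl in place of 2-cyano-2-methylpropyl on a saturated chain carbon, five bonds along the chain from an oxygen on an aromatic ring. Among the measured compounds shown here, two measured steps bear on this. Exchanging the nitrile-bearing chain for a tetrazole gave a number 17 percentage points higher from compound 1 to compound 3 (beyond the scatter), and exchanging carbamoyl for the tetrazole gave a number 12 percentage points higher from compound 2 to compound 3 (beyond the scatter). For the measured compounds named here, compound 4 also carries a tetrazole, but one bearing a methyl, with 0 hydrogen-bond donors, placed on a longer chain; no measured step covers either feature. A modest rise is therefore expected, smaller than that seen for compound 3. The estimate for compound 4 is 20%, in the range 6% to 36%, which is expected to be a number 9 percentage points higher from compound 1 to compound 4 (within the scatter).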

Compound 4, a percentage reported as inhibition, at one concentration (the size of the read-out at that concentration, not a potency): 14%
Beside the measured number, compound 4's estimate is 6 percentage points above it; the measured number falls inside the stated range.
By their numbers in this assay, from the lowest: compounds 1, 4 and 2 (each within the scatter of the next); then compound 3.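

Placing 1-methyl-1-(1-methyl-1H-tetrazol-5-yl)ethyl in place of 2-cyano-2-methylpropyl, five bonds along the chain from an oxygen on an aromatic ring, gave a number 3 percentage points higher from compound 1 to compound 4 (within the scatter) in this assay, so the result does not separate the two groups. Carrying a tetrazole ring is therefore not enough on its own for a number beyond the scatter of compound 1. No measurement shown gives a reason for this result. Going by these compounds, compound 4 differs from compound 3 in both chain length and the methyl on the tetrazole, so the contribution of each remains open. Also open, on these data alone, is how a carboxylic acid would compare with the tetrazole on this longer chain.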